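Chloro for methyl beside the benzimidazole: an estimate

The compounds below may be only part of what the source reports. "The series", "measured", "known", "first", "only" and "open" are said of these compounds alone.

Compound 1 `Cc1ccc(NC(=S)NC(=O)c2ccc(OCc3ccc(C(F)(F)F)cc3)cc2)cc1-c1nc2ccccc2[nH]1`: 6500 nM
Compound 2 `Cc1ccc(NC(=S)NC(=O)c2ccc(OCc3cccc(Cl)c3Cl)cc2)cc1-c1nc2ccccc2[nH]1`: > 100000 nM

Compound 1 gives 6500 nM in a functional assay on MGC-803 cells (Homo sapiens) for inhibition, read by MTT assay, with a stated time of 48 h (on this read-out higher numbers stand for weaker inhibition and lower numbers for stronger inhibition), and that is the only number shown. The one remaining entry is a limit of the assay rather than a number. Compound 2 reaches only the limit of > 100000 nM in this assay. Among the compounds with values here, the one measured step, an at least 15-fold higher number from compound 1 to compound 2 (1.18 log units; beyond the scatter), concerns the benzyl ether end of the shared core and sits at the limit described by the limit of > 100000 nM in this assay, at which 1 of the 2 values shown sits.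

Compound 3 `O=C(NC(=S)Nc1ccc(Cl)c(-c2nc3ccccc3[nH]2)c1)c1ccc(OCc2ccc(C(F)(F)F)cc2)cc1` differs from compound 1 by chloro in place of methyl on an aromatic carbon: the place is on an aromatic carbon of a six-membered aromatic ring of carbon only, ortho to a 1H-benzimidazol-2-yl group, para to a large group. Within the data shown here, no measured step touches this position, so the account expects for compound 3 a step of no change at the digits printed from compound 1 to compound 3 (within the scatter), that is, none beyond the scatter. Compound 3 is therefore estimated at 6500 nM, ranging from 1500 nM to 30000 nM.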

Compound 3, half-maximal inhibitory concentration: 5330 nM
Estimate against measurement, compound 3: 1.2-fold (0.09 log units) above; low and high end bracket the measured number.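

In this assay, within the data shown here, chloro in place of methyl gives a 1.2-fold lower number from compound 1 to compound 3 (0.09 log units; within the scatter), the first reading at this position. The aromatic carbon ortho to a 1H-benzimidazol-2-yl group and para to a large group thus carries either methyl or chloro with no difference beyond the scatter, whereas the earlier step concerned only the benzyl ether end of the shared core. Nothing shown gives a reason for this result.

Among the compounds shown, only methyl and chloro stand at this carbon, so it remains open how an amine, a methoxy group or a carboxylic acid would read there. Also open, on these data alone, is whether chloro at this carbon would read the same with the 2,3-dichlorophenyl group of compound 2 in place of the 4-(trifluoromethyl)phenyl group.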